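Swapping a bromophenyl for a methyl-nitrophenyl in a chalcone amide

The compounds below may be only part of what the source reports. "The series", "measured", "known", "first", "only" and "open" are said of these compounds alone.

Three compounds share one core, differing only in the ring attached to the carbonyl at the end of the double-bonded chain. Compound 1 `COC(=O)c1cc(-c2cccc(NC(=O)c3ccc(/C=C/C(=O)c4cccs4)cc3)c2)on1` carries a thienyl there; in an ADME assay on Vero cells (Chlorocebus sabaeus) for cytotoxicity, read by MTT assay, with a stated time of 72 h (a lower number here means that less compound is tolerated, a higher number that more compound is tolerated), compound 1 has "not determined" (no result reported). Compound 2 `CCOc1ccc(C(=O)/C=C/c2ccc(C(=O)Nc3cccc(-c4cc(C(=O)OC)no4)c3)cc2)cc1` carries an ethoxyphenyl. In this assay compound 2 gives only a limit, > 40 ug/mL. Compound 3 `COC(=O)c1cc(-c2cccc(NC(=O)c3ccc(/C=C/C(=O)c4ccc(Br)cc4)cc3)c2)on1` carries a bromophenyl. In this assay compound 3 likewise gives only a limit, > 20 ug/mL. The step that the two limits leave unreadable from compound 2 to compound 3 therefore cannot be sized: it rests on the limit of > 20 ug/mL in this assay, at which 1 of the 3 values shown sits, and (the limit of > 40 ug/mL in this assay, at which 1 of the 3 values shown sits), and nothing else has a number. Compound 3 thus stands only at a limit, beside one other limit and one entry without a result.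

Compound 4 `COC(=O)c1cc(-c2cccc(NC(=O)c3ccc(/C=C/C(=O)c4ccc(C)c([N+](=O)[O-])c4)cc3)c2)on1` differs from compound 3 by 4-methyl-3-nitrophenyl in place of 4-bromophenyl on a carbonyl carbon. Going by the values given here, no measured step bears on this change with a readable size, so no direction can be read from the data. The expected step that the limit leaves unreadable from compound 3 to compound 4 is estimated to stay within the usual scatter, and compound 4 is expected to give about 30 ug/mL, in the range 10 ug/mL to 80 ug/mL.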

Compound 4, half-maximal cytotoxic concentration: > 80 ug/mL
Compound 4: a limit, no number; the forecaster's own chance of this, stated with the estimate: 55%; middle value at least 2.6-fold (0.42 log units) from the limit.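

In this assay compound 4 gives only a limit, > 80 ug/mL. Going by these compounds alone, with compound 2, compound 3 and compound 4 all resting on limits, no step among them can be read. Still open, as far as these compounds go, is whether changing the ring on the carbonyl shifts the half-maximal cytotoxic concentration at all.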